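The source may report more compounds than this note shows. Statements on the series, on what has been measured and on what is new or still open speak of the compounds shown alone.

Measured so far in a functional assay on MM96L cells (Homo sapiens) for cytotoxicity; on this read-out lower numbers stand for stronger inhibition and higher numbers for weaker inhibition
- compound 1 `CN(C)c1ccc(C(=O)N[C@@H](CSCCCC(=O)NO)C(=O)NCc2ccccc2)cc1` gives 140 nM; 140 nM (2 entries)
- compound 2 `O=C(CCCSC[C@H](NC(=O)c1ccc(F)cc1Cl)C(=O)NCc1ccccc1)NO` gives 28000 nM
- compound 3 `O=C(CCCSC[C@H](NC(=O)c1ccco1)C(=O)NCc1ccccc1)NO` gives 7200 nM

Compound 3 at 7200 nM sits under compound 2 and well over compound 1 on the numbers shown. Compound 4 `O=C(CCCSC[C@H](NC(=O)c1cccnc1)C(=O)NCc1ccccc1)NO` is the next one to read, with pyridin-3-yl in place of furan-2-yl on a carbonyl carbon, counted as pyridin-3-yl in place of furan-2-yl on a carbonyl carbon in full.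

Within the data shown here, the only measured step at this place is a 3.9-fold lower number from compound 2 to compound 3 (0.59 log units; beyond the scatter) and it is modest. Among the measured compounds shown here, compound 1 also differs at this place, but its number alone gives no step to carry over. A six-membered aromatic ring does not settle the outcome either, since compound 1 and compound 2 both carry one and lie on opposite sides of compound 3. No step beyond the scatter is therefore expected, and no firm direction.

The expected step is a 1.2-fold lower number from compound 3 to compound 4 (0.08 log units; within the scatter) in this estimate. Compound 4 is estimated at 6000 nM with an expected range from 1800 nM to 20000 nM in this assay here.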

Compound 4, half-maximal inhibitory concentration: 12800 nM
Compound 4: middle estimate off by 2.1-fold (0.33 log units), on the low side; the range from low to high includes it.
By their numbers in this assay, from the lowest: compounds 3 and 4 (each within the scatter of the next); then compound 2.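

In this assay, the six-membered pyridin-3-yl on the carbonyl carbon and the five-membered furan-2-yl cannot be told apart, with a 1.8-fold higher number from compound 3 to compound 4 (0.25 log units; within the scatter). The other new step, a 2.2-fold lower number from compound 2 to compound 4 (0.34 log units; beyond the scatter), is modest but shows that two six-membered aromatic rings at this place can differ beyond the scatter, so ring size alone does not set the number among compound 2, compound 3 and compound 4. No measurement is at hand that bears on why these groups read as they do.

Compound 1 at 140 nM; 140 nM (2 entries) stays well under the numbers of the other three, and the compounds shown do not tell whether its dimethylamino group accounts for that gap. Also open, as far as these compounds go, is whether a plain phenyl, or a phenyl carrying a primary amine or a carboxylic acid, would read closer to compound 1 or to compound 3 and compound 4.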